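A Methyl Added to the Pyridine of Compound 1

The compounds below may be only part of what the source reports. "The series", "measured", "known", "first", "only" and "open" are said of these compounds alone.

Compound 1 `CN1C(=O)C2=C(C1=O)N(CC(=O)Nc1ccc(-c3cccnc3)nn1)CCC2` is examined in an ADME assay on microsomes from liver (Homo sapiens) for metabolic stability (a lower number here means slower removal, a higher number faster removal of the compound), where compound 1 gives 7 mL.min-1.g-1. Compound 2 `CN1C(=O)C2=C(C1=O)N(CC(=O)Nc1ccc(-c3ccncc3)cc1)CCC2` gives 31 mL.min-1.g-1 in this assay, so compound 1 stands at the lowest of the two numbers, with the gap to compound 2 lying beyond the scatter. Compound 3 `Cc1ccc(-c2ccc(NC(=O)CN3CCCC4=C3C(=O)N(C)C4=O)nn2)cn1` differs from compound 1 by methyl in place of hydrogen on an aromatic carbon. Going by the values given here, no measured pair shows this change, so the step of a 1.4-fold higher number from compound 1 to compound 3 (0.15 log units; within the scatter) is expected to be small, probably upward but possibly within the scatter. For compound 3 the estimate is 10 mL.min-1.g-1, within a range from 4 mL.min-1.g-1 to 25 mL.min-1.g-1.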

Compound 3, intrinsic clearance in microsomes in the liver assay: 8 mL.min-1.g-1
Estimate against measurement, compound 3: 1.3-fold (0.10 log units) above, within the range that was stated.
By their numbers in the liver assay, from the lowest: compounds 1 and 3 (each within the scatter of the next); then compound 2.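

In the liver assay, the change from pyridin-3-yl to 6-methylpyridin-3-yl gives a 1.1-fold higher number from compound 1 to compound 3 (0.06 log units; within the scatter), so methyl at this place next to the ring nitrogen leaves that number within the scatter. In a physicochemical assay for solubility, measured as thermodynamic solubility, at pH 4 (a lower number here means a less soluble compound, a higher number a more soluble compound), the same change gives an at least 13-fold higher number from compound 1 to compound 3 (1.14 log units; beyond the scatter), a large step beyond the scatter. In the physicochemical assay compound 1 gives 13.9 ug/mL. In the physicochemical assay compound 3 gives > 194 ug/mL, which is a limit of the assay and not a number.

From the compounds shown here alone, whether an ethyl or a methoxy group at this place would give the same picture in both assays stays open. So does what methyl would do on the other carbons of that ring.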